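The source may report more compounds than this note shows. Statements on the series, on what has been measured and on what is new or still open speak of the compounds shown alone.

Measured so far:
- compound 1 `CCC(=O)c1ccc2c(c1)C(n1ccccc1=O)=CC(C)(C)O2` — 5.85
- compound 2 `CC1(C)C=C(n2ccccc2=O)c2cc(C(=O)c3ccco3)ccc2O1` — 5.92

Both compounds were tested in a functional assay (trachea) with Rattus norvegicus as the target; a lower number here means a less potent compound, a higher number a more potent compound, by a factor of ten per unit of this negative logarithm. Among the compounds with values here, compound 2 has the higher of the two numbers, with compound 1 at 5.85 close behind; the single step of a number 0.07 log units higher from compound 1 to compound 2 (within the scatter) lies within the scatter, so the two results cannot be told apart. The change from compound 1 to compound 2, furan-2-yl in place of ethyl on a carbonyl carbon, therefore left the read-out unchanged within the scatter.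

Compound 3 `CC1(C)C=C(n2ccccc2=O)c2cc(C(=O)c3ccc(O)cc3)ccc2O1` has not yet been measured in this assay. It differs from compound 2 in one place: 4-hydroxyphenyl in place of furan-2-yl on a carbonyl carbon. Within the data shown here, no measured step covers this exact exchange. Among the measured compounds shown here, the only step available, a number 0.07 log units higher from compound 1 to compound 2 (within the scatter), shows that swapping the group on this carbonyl carbon once before made no difference beyond the scatter. On that basis, the step of a number 0.02 log units lower from compound 2 to compound 3 (within the scatter) is expected to be small, with no clear direction. Compound 3 is therefore estimated at 5.9, within a range from 5.3 to 6.5.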

Compound 3, logarithm of the reciprocal of the active concentration, log(1/C): 5.87
Compound 3: the middle estimate sits 0.03 log units above what was measured; measured number inside the range.
By their numbers in this assay, from the lowest: compounds 1, 3 and 2 (each within the scatter of the next).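

In this assay, the group on this carbonyl carbon has now been ethyl, furan-2-yl and 4-hydroxyphenyl, and the new comparisons read a number 0.05 log units lower from compound 2 to compound 3 (within the scatter) and a number 0.02 log units higher from compound 1 to compound 3 (within the scatter). This exchange goes further than the earlier one: a six-membered aromatic ring of carbon only, with more heavy atoms than furan-2-yl and carrying a hydrogen-bond donor, takes the place of a five-membered aromatic ring without a donor, and the result still cannot be told apart from the others. No measurement shown here explains why these three groups give results so close together.

The compounds shown leave open whether an amine, a carboxylic acid or a longer chain on this carbonyl carbon would move the number beyond the scatter. On these data alone, it is also open whether plain phenyl would read the same as 4-hydroxyphenyl, which would show whether the hydroxyl group matters at all here.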